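Changing the Amide Group at the Chain Carbon of Compound 3

The source may report more compounds than this note shows. Statements on the series, on what has been measured and on what is new or still open speak of the compounds shown alone.

Measured in an assay on isolated protein for displacement of a labelled ligand from 5-hydroxytryptamine receptor 6 (Homo sapiens); a lower number here means a stronger inhibitor, a higher number a weaker inhibitor:
compound 1 `O=C1CN(C[C@@H]2CCCc3cc(S(=O)(=O)c4cccc(F)c4)ccc32)CCN1` gives 6.31 nM
compound 2 `COCCNC[C@@H]1CCCc2cc(S(=O)(=O)c3cccc(F)c3)ccc21` gives 0.251 nM
compound 3 `CC(=O)N(C)C[C@@H]1CCCc2cc(S(=O)(=O)c3cccc(F)c3)ccc21` gives 1.59 nM

Compound 3 holds the second highest number of the three: a 4.0-fold lower number from compound 1 to compound 3 (0.60 log units; beyond the scatter), while a 6.3-fold higher number from compound 2 to compound 3 (0.80 log units; beyond the scatter). Compound 4 `O=C(CO)NC[C@@H]1CCCc2cc(S(=O)(=O)c3cccc(F)c3)ccc21` differs from compound 3 in one place: ((hydroxymethyl)carbonyl)amino in place of acetyl(methyl)amino on a saturated chain carbon bound to a saturated ring carbon. Within the data shown here, no measured step swaps one amide for another at this carbon; the known steps exchange an amine for an amide or one amine for another, as in a 25-fold lower number from compound 1 to compound 2 (1.40 log units; beyond the scatter). Both compound 3 and compound 4 keep the carbonyl at that carbon, and in this assay a small step is expected, a 1.6-fold higher number from compound 3 to compound 4 (0.20 log units; within the scatter). Compound 4 is estimated at 2.5 nM, within a range from 0.6 nM to 10 nM.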

Compound 4, inhibition constant: 0.1 nM
Estimate against measurement, compound 4: 25-fold (1.40 log units) above, and the stated range ends above it.
By their numbers in this assay, from the lowest: compound 4; then compound 2; then compound 3; then compound 1.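

In this assay, exchanging one amide for another at this carbon can have a large effect (a 16-fold lower number from compound 3 to compound 4 (1.20 log units; beyond the scatter)), which the earlier amine and amide swaps did not reveal. An amide here can also give a lower number than the amine of compound 2 (a 2.5-fold lower number from compound 2 to compound 4 (0.40 log units; beyond the scatter)), and the distance from the 3-oxopiperazin-1-yl group is larger still (a 63-fold lower number from compound 1 to compound 4 (1.80 log units; beyond the scatter)). No supporting measurement explains these steps.

From the compounds shown here alone, the step from compound 3 to compound 4 changes both the nitrogen's methyl and the acetyl group, so their separate contributions remain open. An acetylamino group, with the amide hydrogen but no hydroxyl, would help separate them.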